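The source may hold more compounds than are shown below. What is called first, only, known or untested is meant among the compounds shown, and "the series" means these compounds.

Measured compounds in a functional assay on MCF7 cells (Homo sapiens), tested at 2.5 uM; on this read-out lower numbers stand for a stronger effect and higher numbers for a weaker effect at the one concentration tested:
compound 1 `C=CCOc1c(C)c(C)c2c(c1C)CCC(C)(COc1ccc(/C=C3\SC(=O)NC3=O)cc1OCC)O2` gives 107%
compound 2 `CC(C)=CCOc1c(C)c(C)c2c(c1C)CCC(C)(COc1ccc(/C=C3\SC(=O)NC3=O)cc1Br)O2` gives 96%
compound 3 `CC(C)=CCOc1c(C)c(C)c2c(c1C)CCC(C)(COc1ccc(/C=C3\SC(=O)NC3=O)cc1-c1ccc(F)cc1)O2` gives 87%

Compound 3 holds the lowest of the three numbers. Its nearest neighbour is compound 2: the step of a number 9 percentage points lower from compound 2 to compound 3 (within the scatter) lies within the scatter, so the two cannot be ordered against each other. The gap from compound 3 to compound 1 is beyond the scatter, but compound 1 differs from compound 3 in more than one place, so only the two values as such can be set side by side.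

Among the compounds with values here, compound 4 `CC(C)=CCOc1c(C)c(C)c2c(c1C)CCC(C)(COc1ccc(/C=C3\SC(=O)NC3=O)cc1)O2` is not yet measured. hydrogen in place of 4-fluorophenyl on an aromatic carbon The only measured step that touches the same aromatic carbon is a number 9 percentage points lower from compound 2 to compound 3 (within the scatter), which stayed within the scatter; it runs from bromo to 4-fluorophenyl, not to hydrogen, and no measured compound carries hydrogen at that carbon. Taking away the 4-fluorophenyl is therefore expected to give at most a small step in this assay, a number 8 percentage points higher from compound 3 to compound 4 (within the scatter), toward a higher number if anything and not clearly beyond the scatter. Compound 4 is estimated at 95%, with a range from 80% to 110%.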

Compound 4, a percentage reported as activity, at one concentration (the size of the read-out at that concentration, not a potency): 76%
Beside the measured number, compound 4's estimate is 19 percentage points above it; the whole stated range lies above it.
By their numbers in this assay, from the lowest: compound 4; then compounds 3 and 2 (each within the scatter of the next); then compound 1.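

In this assay this aromatic carbon now gives steps beyond the scatter: a number 11 percentage points lower from compound 3 to compound 4 (beyond the scatter) follows from hydrogen in place of 4-fluorophenyl, and a number 20 percentage points lower from compound 2 to compound 4 (beyond the scatter) follows from hydrogen in place of bromo, both modest and both toward the stronger effect. Bromo and 4-fluorophenyl could not be ordered against each other, so the earlier pair showed no sensitivity at this carbon; with hydrogen as the reference, both groups now sit on the weaker side, and the two differ greatly in size of group without separating in the read-out. No measurement on hand offers an explanation for these steps.

Whether any group at this carbon can match hydrogen remains open, for instance a methoxy, an amine or a carboxylic acid, and the three groups shown cannot say if the read-out follows anything about the group beyond its presence. On these data alone, all numbers come from a single concentration, so it also stays open whether the modest steps seen here would carry over to a potency measured across a range of concentrations.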